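Removing a Benzyl Ether in a Thiophene Series

The source may report more compounds than this note shows. Statements on the series, on what has been measured and on what is new or still open speak of the compounds shown alone.

Compound 1, `COc1ccc(-c2sccc2-c2cc(OC)c(OC)c(OC)c2)cc1OCc1ccccc1`, gives in a functional assay on SGC-7901 cells (Homo sapiens) for antiproliferative activity, read by MTT assay, with a stated time of 72 h (a lower number here means a stronger inhibitor, a higher number a weaker inhibitor), a value of > 100000 nM, which is a limit of the assay and not a number.
Compound 2, `COc1ccc(-c2sccc2-c2cc(OC)c(OC)c(OC)c2)cc1O`, gives 580 nM in this assay.
Compound 3, `COc1ccc(-c2cc(C(=O)O)sc2-c2cc(OC)c(OC)c(OC)c2)cc1OCc1ccccc1`, gives > 100000 nM in this assay, again a limit of the assay rather than a number.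

Compound 1 and compound 2 differ by one change, (hydrogen in place of benzyl on an oxygen on an aromatic ring), and that change made a large step: an at least 170-fold lower number from compound 1 to compound 2 (2.23 log units; beyond the scatter). Two of the three values sit at the limit of > 100000 nM in this assay, at which 2 of the 3 values shown sit, so the series is known more by its inactive members than by its active ones.

Compound 4, `COc1ccc(-c2cc(C(=O)O)sc2-c2cc(OC)c(OC)c(OC)c2)cc1O`, carries the same change relative to compound 3, (hydrogen in place of benzyl on an oxygen on an aromatic ring), at the same kind of place. How the core of compound 3 differs from the core of compound 1 is not broken down here. Among the compounds with values here, since compound 3 stands only at a limit, the step cannot be measured from a known starting number, and the expected step, an at least 12-fold lower number from compound 3 to compound 4 (1.09 log units; beyond the scatter), is an estimate that rests on the one measured instance. Compound 4 is therefore expected to give about 8000 nM, somewhere between 600 nM and 100000 nM.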

Compound 4, half-maximal inhibitory concentration: 17500 nM
For compound 4 the middle estimate is 2.2-fold (0.34 log units) below the measured one; the range from low to high includes it.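

In this assay, hydrogen in place of benzyl on an oxygen on an aromatic ring again lowered the number on the core of compound 3, giving an at least 5.7-fold lower number from compound 3 to compound 4 (0.75 log units; beyond the scatter), so the direction seen on the core of compound 1 held on a second core. Set side by side, the two steps read: the same change on two cores in this assay, an at least 170-fold lower number (2.23 log units; beyond the scatter) from compound 1 to compound 2 and an at least 5.7-fold lower number (0.75 log units; beyond the scatter) from compound 3 to compound 4; the limit leaves it open whether they differ. Both steps start from a limit of the assay, so the series shows a shared direction on these two cores but does not show that the size of the step carries from one core to the other, and two cores make no general rule.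

The compounds shown leave open whether a methyl ester or an amide in place of the carboxylic acid of compound 4 would change the value in this assay. They also leave open whether an amine in place of the hydroxy group would keep the activity that appears when the benzyl group leaves.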